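Sulfonamide Replaced by Sulfone on a Shared Core

A few compounds are considered here, and "the series" means these few. Any claim that something is new, unique, unknown or untested is made for them only; others in the source may bear on it.

Compound 1 `Cn1c(=O)c(S(=O)(=O)Nc2ccc(F)cc2F)cc2cnc(Nc3ccc4[nH]ccc4c3)nc21` gives 5000 nM in a functional assay on DU-145 cells (Homo sapiens) for inhibition, read by trypan blue exclusion, with a stated time of 72 h (a lower number here means a stronger inhibitor, a higher number a weaker inhibitor), the highest of the two numbers recorded. Compound 2 `Cn1c(=O)c(S(=O)(=O)c2ccccc2)cc2cnc(Nc3cnc4[nH]ccc4c3)nc21`, which carries a different amine on the shared core, gives 1000 nM in this assay, a gap beyond the scatter. Compound 3 `Cn1c(=O)c(S(=O)(=O)c2ccc(F)cc2)cc2cnc(Nc3ccc4[nH]ccc4c3)nc21` is not yet measured; it differs from compound 1 by 4-fluorophenyl in place of (2,4-difluorophenyl)amino on a sulfonyl sulfur. Because compound 2 gives 1000 nM, a step toward lower numbers is expected for compound 3, of about a 3.3-fold lower number from compound 1 to compound 3 (0.52 log units; beyond the scatter). Compound 3 is therefore estimated at 1500 nM, within 500 nM to 5000 nM.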

Compound 3, half-maximal inhibitory concentration: 300 nM
The estimate for compound 3 lay 5.0-fold (0.70 log units) above the measured number; measured number outside the range, below it.
By their numbers in this assay, from the lowest: compound 3; then compound 2; then compound 1.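

For the compounds shown here, compound 3 and compound 1 form the first pair here that differs in one place, and in this assay the change on the sulfonyl sulfur gives a large step, a 17-fold lower number from compound 1 to compound 3 (1.22 log units; beyond the scatter), beyond the scatter. Compound 2 differs from compound 1 in more than one place, so it could not isolate this change. The step replaces the amino link and removes one fluorine together, so the two cannot be separated here.

A 2,4-difluorophenyl or (4-fluorophenyl)amino group on the sulfonyl sulfur would separate them, but neither is among the compounds shown. No measurement shown explains the size of this step.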